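A few compounds are considered here, and "the series" means these few. Any claim that something is new, unique, unknown or untested is made for them only; others in the source may bear on it.

Measured compounds:

Compound 1 `OCCC#Cc1ccccc1C#Cc1ccccc1`, which in a functional assay on SF-295 cells (Homo sapiens) for cytotoxicity (a lower number here means a stronger inhibitor of growth, a higher number a weaker inhibitor of growth), gives 28100 nM.
Compound 2 `OCCCCC#Cc1ccccc1C#Cc1ccccc1`, which in this assay gives 150 nM.
Compound 3 `CSc1ccccc1C#Cc1ccccc1C#CCCCCO`, which in this assay gives 1500 nM.

Among these three, compound 2 has the lowest number, so it is the strongest inhibitor of growth of the set. Its nearest neighbour is compound 3, separated by a step of a 10-fold higher number from compound 2 to compound 3 (1.00 log units; beyond the scatter). Its furthest neighbour is compound 1, and the step of a 190-fold lower number from compound 1 to compound 2 (2.27 log units; beyond the scatter) is by far the largest change seen here, brought by lengthening the chain that carries the hydroxy group.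

Compound 4 `COc1cccc(C#Cc2ccccc2C#CCCCCO)c1` differs from compound 2 by methoxy in place of hydrogen on an aromatic carbon. Within the data shown here, no measured step has exactly this change. The step that comes closest is a 10-fold higher number from compound 2 to compound 3 (1.00 log units; beyond the scatter), where a small group also entered on an aromatic carbon of compound 2 and the number rose moderately. On that basis compound 4 is expected to show a modest rise in the number, roughly a 3.0-fold higher number from compound 2 to compound 4 (0.48 log units; beyond the scatter), with the direction more certain than the size. The estimate for compound 4 is therefore 450 nM, within a range of 120 nM to 1800 nM.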

Compound 4, concentration for 50% growth inhibition: 7900 nM
Estimate against measurement, compound 4: 18-fold (1.24 log units) below; measured number outside the range, above it.
By their numbers in this assay, from the lowest: compound 2; then compound 3; then compound 4; then compound 1.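

In this assay, methoxy in place of hydrogen on an aromatic carbon, meta to a large group, gives a 53-fold higher number from compound 2 to compound 4 (1.72 log units; beyond the scatter). This shows that a group of only 2 heavy atoms can cost compound 2 much of its growth inhibition at this position. The earlier step, a 10-fold higher number from compound 2 to compound 3 (1.00 log units; beyond the scatter), also went toward weaker inhibition but was only modest, so it gave no sign that an added group on an aromatic carbon could bring a large loss, and nothing at hand explains this loss.

The compounds shown leave open whether methoxy on a different carbon of this ring would cost as much. They also leave open how fluorine, an amine or a carboxylic acid would behave at the position that carries methoxy in compound 4.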